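Swapping a saturated amide chain for an unsaturated ester chain

A few compounds are considered here, and "the series" means these few. Any claim that something is new, unique, unknown or untested is made for them only; others in the source may bear on it.

Three compounds have been measured in an assay on a protein complex for inhibition of CDK8/Cyclin C (Homo sapiens), with a stated time of 1 h; a higher number here means a weaker inhibitor, a lower number a stronger inhibitor:

Compound 3, `CNC(=O)CCc1ccncc1-c1ccc2ccccc2c1`, gives 21.1 nM.
Compound 2, `COC1CN(C(=O)/C=C/c2ccncc2-c2ccc3ccccc3c2)C1`, gives 42.8 nM.
Compound 1, `CCOC(=O)/C=C/c1ccncc1-c1ccc2[nH]ccc2c1`, gives 107 nM.

Compound 3 has the lowest of the three numbers, which here means the strongest inhibition. Compound 2 sits closest to it, with a higher number, a gap beyond the usual scatter, and compound 1 is furthest away, again beyond the scatter. No two of these compounds differ in just one place, so none of the gaps can be tied to a single change.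

Compound 4, `COC(=O)/C=C/c1ccncc1-c1ccc2ccccc2c1`, has not yet been measured in this assay. Compared with compound 3 it carries 2-(methoxycarbonyl)ethenyl in place of 2-(methylcarbamoyl)ethyl on an aromatic carbon. The chain keeps its length but loses its hydrogen-bond donor and gains a second double bond outside the aromatic rings. Among the measured compounds, those with an unsaturated chain, compound 2 and compound 1, both gave higher numbers than compound 3, though other parts of their structures also differ, so this is only a hint. On that basis a modest weakening is expected, with a 2.4-fold higher number from compound 3 to compound 4 (0.37 log units; beyond the scatter) lying beyond the scatter but not far beyond it. The estimate for compound 4 in this assay is 50 nM, with a plausible range from 15 nM to 160 nM.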

Compound 4, half-maximal inhibitory concentration: 40.6 nM
Estimate against measurement, compound 4: 1.2-fold (0.09 log units) above; the measured number falls inside the stated range.
By their numbers in this assay, from the lowest: compounds 3, 4 and 2 (each within the scatter of the next, the first and the last beyond it); then compound 1.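

In this assay, the step on the aromatic carbon opposite the ring nitrogen, 2-(methoxycarbonyl)ethenyl in place of 2-(methylcarbamoyl)ethyl, gives a 1.9-fold higher number from compound 3 to compound 4 (0.28 log units; within the scatter), so this position tolerates losing the amide hydrogen and gaining a double bond in the chain with no shift that can be told from the scatter. The second step stays on the unsaturated chain and exchanges only the group on its carbonyl carbon: methoxy in place of 3-methoxyazetidin-1-yl gives a 1.1-fold lower number from compound 2 to compound 4 (0.02 log units; within the scatter), which shows that the two groups cannot be told apart in this assay. There is no measured information that explains either result.

As far as these compounds go, the first step changes the hydrogen-bond donor and the double bond together, so the separate contribution of each remains open, and a 2-(methoxycarbonyl)ethyl chain or a 2-(methylcarbamoyl)ethenyl chain could pull the two apart. Also open is what a carboxylic acid, an amine or a longer chain would do at this position, since the compounds shown cover only esters and amides with chains of this length.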